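Aryl swap from compound 3 to compound 4

The source may report more compounds than this note shows. Statements on the series, on what has been measured and on what is new or still open speak of the compounds shown alone.

Values in a functional assay on MCF7 cells (Homo sapiens) for cytotoxicity, read by MTT assay, with a stated time of 72 h; a lower number here means a stronger inhibitor, a higher number a weaker inhibitor:
- compound 1 `COc1cccc(/C=C2\CCC/C(=C\c3ccc(Cl)cc3)C2=O)c1OC`: 10300 nM
- compound 2 `COc1cccc(/C=C2\CCC/C(=C\c3cccc(OC)c3OC)C2=O)c1`: 5900 nM
- compound 3 `COc1ccc(/C=C2\CCC/C(=C\c3cccc(OC)c3OC)C2=O)cc1`: 18600 nM

Compound 3 stands at 18600 nM in this assay. Two measured steps place it: a 3.2-fold higher number from compound 2 to compound 3 (0.50 log units; beyond the scatter), and a 1.8-fold higher number from compound 1 to compound 3 (0.26 log units; within the scatter). The first separates it from compound 2, while the second leaves it level with compound 1.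

Compound 4 `COc1cccc(/C=C2\CCC/C(=C\c3ccc(Cl)c(Cl)c3)C2=O)c1OC` has 3,4-dichlorophenyl in place of 4-methoxyphenyl on a double-bonded chain carbon bound to a double-bonded ring carbon. Within the data shown here, no measured compound carries 3,4-dichlorophenyl, so the expectation rests on indirect evidence. The nearest guide is a 1.8-fold higher number from compound 1 to compound 3 (0.26 log units; within the scatter), a swap of chloro for methoxy on an aromatic carbon. Read in reverse, it suggests a small move towards a lower number. The other measured change at this place, a 1.7-fold lower number from compound 1 to compound 2 (0.24 log units; within the scatter), is also small. Only a 3.2-fold higher number from compound 2 to compound 3 (0.50 log units; beyond the scatter) exceeds the scatter, and it involves no chlorine-bearing group.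

A modest shift towards a lower number, not clearly beyond the scatter, is therefore expected. The expected change is a 1.9-fold lower number from compound 3 to compound 4 (0.27 log units; within the scatter). For compound 4 the estimated value is 10000 nM, with an expected range of 4000 nM to 22000 nM.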

Compound 4, half-maximal inhibitory concentration: 9000 nM
For compound 4 the middle estimate is 1.1-fold (0.05 log units) above the measured one; the measured number falls inside the stated range.
By their numbers in this assay, from the lowest: compounds 2, 4, 1 and 3 (each within the scatter of the next, the first and the last beyond it).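

In this assay a chlorine-bearing aryl group at this place now separates from 4-methoxyphenyl beyond the scatter, with 3,4-dichlorophenyl in its place (a 2.1-fold lower number from compound 3 to compound 4 (0.32 log units; beyond the scatter)), which the earlier chloro and methoxy pair did not show. The second chlorine does not register, since chloro in place of hydrogen on an aromatic carbon stays within the scatter (a 1.1-fold lower number from compound 1 to compound 4 (0.06 log units; within the scatter)), and 3,4-dichlorophenyl also stays level with 3-methoxyphenyl (a 1.5-fold higher number from compound 2 to compound 4 (0.18 log units; within the scatter)), so compound 3 stands apart from compound 2 and compound 4 but not from compound 1. No measurement on hand offers an explanation for these differences.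

Every aryl group shown at this place carries only chloro or methoxy, so it remains open how an amine or a carboxylic acid on that ring would read in this assay. It is also open whether the step to 3,4-dichlorophenyl would hold with 3-methoxyphenyl or 4-methoxyphenyl on the other side of the core, as the only dichloro compound shown, compound 4, keeps the dimethoxy-substituted aryl group of compound 1.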